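Adding a Methyl on Two Related Cores

The source may hold more compounds than are shown below. What is called first, only, known or untested is meant among the compounds shown, and "the series" means these compounds.

Compound 1 `CCNC(=O)Nc1cccc(S(=O)(=O)Oc2ccccc2CC)c1` and compound 2 `CCCc1ccccc1OS(=O)(=O)c1cccc(NC(=O)NCC)c1` share one core. In a functional assay on MCF7 cells (Homo sapiens) for cytotoxicity, read by sulforhodamine B assay, with a stated time of 48 h (a higher number here means a weaker inhibitor, a lower number a stronger inhibitor), compound 1 gives 31000 nM, and compound 2 gives 24000 nM. The change between them is methyl in place of hydrogen on a saturated chain carbon, two bonds along the chain from an aromatic carbon, and it made a step of a 1.3-fold lower number from compound 1 to compound 2 (0.11 log units; within the scatter). Compound 3 `CCNC(=O)Nc1ccc(S(=O)(=O)Nc2ccccc2C)cc1` rests on a second core; the difference between the two cores is not broken down here. In this assay compound 3 reaches only a limit of the assay, > 200000 nM. Compound 4 `CCNC(=O)Nc1ccc(S(=O)(=O)Nc2ccccc2CC)cc1` differs from compound 3 by methyl in place of hydrogen on a saturated chain carbon bound to an aromatic carbon. This is the same kind of change as that from compound 1 to compound 2, yet the place differs: there the saturated chain carbon lay two bonds along the chain from an aromatic carbon, here it is bound to an aromatic carbon. Because a 1.3-fold lower number from compound 1 to compound 2 (0.11 log units; within the scatter) stayed within the scatter, only a small step is expected for compound 4, namely a number no higher from compound 3 to compound 4 (the limit leaves the size open). With the limit of > 200000 nM in this assay, at which 1 of the 3 values shown sits, in view, the value expected for compound 4 is 200000 nM, likely reported again only as a limit, within a range from 100000 nM to 400000 nM.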

Compound 4, half-maximal inhibitory concentration: 91000 nM
For compound 4 the middle estimate is 2.2-fold (0.34 log units) above the measured one; measured number outside the range, below it.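

In this assay, methyl in place of hydrogen on a saturated chain carbon bound to an aromatic carbon gave an at least 2.1-fold lower number from compound 3 to compound 4 (0.34 log units; beyond the scatter). On these data alone, compound 3 is held only by a limit of the assay, > 200000 nM, so the true size of this step stays unknown. The change therefore moved the number beyond the scatter on the core of compound 3 but not on the core of compound 1, at a different place on the chain in each case, and this does not show that the two cores truly respond differently: the same change on two cores in this assay, a 1.3-fold lower number (0.11 log units; within the scatter) from compound 1 to compound 2 and an at least 2.1-fold lower number (0.34 log units; beyond the scatter) from compound 3 to compound 4; the limit leaves it open whether they differ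

The compounds shown leave open how a longer chain, such as butyl, would read at this place on either core, and whether a propyl chain on the core of compound 3 would extend the step seen there. They also leave open what a polar group such as an amine or a carboxylic acid at the end of the chain would do.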